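Halogen steps as a guide to bromo compound 4

The source may report more compounds than this note shows. Statements on the series, on what has been measured and on what is new or still open speak of the compounds shown alone.

In a functional assay on CCRF-CEM cells (Homo sapiens) for inhibition (a higher number here means a weaker inhibitor, a lower number a stronger inhibitor), compound 1 (`O=C1CCCCC/C1=C\c1ccccc1`) gives 110000 nM. Compound 2 (`O=C1CCCCC/C1=C\c1ccc(F)cc1`) gives 198000 nM, within the scatter of compound 1, while compound 3 (`O=C1CCCCC/C1=C\c1ccc(Cl)cc1`) gives 43500 nM. Compound 1 thus stands with compound 2, and compound 3 has the lowest number of the three.

Compound 4 (`O=C1CCCCC/C1=C\c1cccc(Br)c1`) is not yet measured. It differs from compound 1 by bromo in place of hydrogen on an aromatic carbon.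

Fluoro in place of hydrogen gave a 1.8-fold higher number from compound 1 to compound 2 (0.26 log units; within the scatter). Chloro in place of hydrogen gave a 2.5-fold lower number from compound 1 to compound 3 (0.40 log units; beyond the scatter), and chloro in place of fluoro gave a 4.6-fold lower number from compound 2 to compound 3 (0.66 log units; beyond the scatter). Within the data shown here, no measured compound carries bromo, and none has a halogen at this ring place, so the guidance is weak. Among the measured compounds shown here, the chloro step of compound 3 is taken as the nearest precedent, and a modest step to a lower number is expected. The expected step is a 2.2-fold lower number from compound 1 to compound 4 (0.34 log units; beyond the scatter), though a result within the scatter would not surprise. For compound 4 the estimated value is 50000 nM, with an expected range of 20000 nM to 130000 nM.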

Compound 4, half-maximal inhibitory concentration: 137000 nM
Compound 4: middle estimate off by 2.7-fold (0.44 log units), on the low side, and the stated range ends below it.
By their numbers in this assay, from the lowest: compound 3; then compounds 1, 4 and 2 (each within the scatter of the next).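

Bromo at this ring place, on an aromatic carbon meta to a group of 9 heavy atoms, gives in this assay a 1.2-fold higher number from compound 1 to compound 4 (0.10 log units; within the scatter) and so leaves no readable change. The step therefore resembles the fluoro step, a 1.8-fold higher number from compound 1 to compound 2 (0.26 log units; within the scatter) and within the scatter as well, rather than the chloro step, a 2.5-fold lower number from compound 1 to compound 3 (0.40 log units; beyond the scatter) and beyond it, though both of those halogens sit at a different ring place. No measurement offered here bears on why the bromo step stays within the scatter.

Going by these compounds, whether the lower number of compound 3 belongs to chloro itself or to its ring place stays open, since compound 3 and compound 4 differ in two places. Also open, on these data alone, is whether an amine or a carboxylic acid at the ring place of compound 4 would shift the number at all.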